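Replacing the Aryl Group on Sulfur in Compound 1

The compounds below may be only part of what the source reports. "The series", "measured", "known", "first", "only" and "open" are said of these compounds alone.

Measured so far in a functional assay on HeLa cells (Homo sapiens) for inhibition, read by CCK-8 assay, with a stated time of 72 h, tested at 2 uM; a higher number here means more inhibition of growth at the concentration tested, a lower number less inhibition of growth:
compound 1 `COc1ccc(SCc2ccc(/C=C/C(=O)Nc3ccccc3N)cc2)cc1OC`: 10.1%
compound 2 `Nc1ccccc1NC(=O)c1ccc(CSc2ccc(F)cc2)cc1`: 27.9%
compound 3 `Nc1ccccc1NC(=O)c1ccc(CSCCc2ccccc2)cc1`: 27.7%

Compound 1 stands lowest of the three numbers in this assay, and its gaps to compound 2 and to compound 3 both lie beyond the usual scatter. Compound 2 and compound 3 share a core that differs from the core of compound 1, so their values set no direct reference for it.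

The unmeasured compound 4 `CCc1ccc(SCc2ccc(/C=C/C(=O)Nc3ccccc3N)cc2)cc1` keeps the core of compound 1 and changes only the group on the sulfur: 4-ethylphenyl in place of 3,4-dimethoxyphenyl on a sulfur. Among the compounds with values here, the one measured step that bears on such a change is a number 0.2 percentage points lower from compound 2 to compound 3 (within the scatter), where the aryl group on the sulfur was exchanged on the other core and the number barely moved. Taken on its own, this step gives no reason to expect more than a small shift in this assay for compound 4, and its direction cannot be told from the data.

Compound 4 is therefore expected to land close to compound 1, with a step of a number 3.9 percentage points higher from compound 1 to compound 4 (within the scatter) in this assay. The estimate for compound 4 is 14%, with a range from 3% to 30%.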

Compound 4, percent growth inhibition at one concentration: 3.96%
Compound 4: middle estimate off by 10 percentage points, on the high side, and the stated range covers the measured number.
By their numbers in this assay, from the lowest: compounds 4 and 1 (each within the scatter of the next); then compounds 3 and 2 (each within the scatter of the next).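

On the core of compound 1, the group on the sulfur has now been exchanged directly, and in this assay the swap gives a number 6.1 percentage points lower from compound 1 to compound 4 (within the scatter) even though the 3,4-dimethoxyphenyl group, with both of its oxygen atoms and its 2 hydrogen-bond acceptors, gives way to 4-ethylphenyl, which has only carbon in its 8 heavy atoms. Within the data shown here, until now, the only exchange on this sulfur was on another core, so this is the first sign that, on the core of compound 1, the reading at this one concentration does not depend on those oxygen atoms. No supporting evidence is available to explain why the number holds across this change.

On these data alone, whether any group on this sulfur can lift the number on the core of compound 1 stays open, since both groups seen there are substituted phenyl rings, and an amine or a carboxylic acid on that ring could behave differently. As far as these compounds go, it is also open whether phenethyl, which on the other core reads much like 4-fluorophenyl, would give a similar number on the core of compound 1.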